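Phenyl on the ring oxygen: compound 1 to compound 3

A few compounds are considered here, and "the series" means these few. Any claim that something is new, unique, unknown or untested is made for them only; others in the source may bear on it.

Compound 1 `CC1=C(C(=O)Nc2ccc(Cl)c(Cl)c2)C(c2cccc(O)c2)NC(=S)N1` and compound 2 `CC1=C(C(=O)Nc2ccc(Cl)c(Cl)c2)C(c2cccc(Cl)c2)NC(=O)N1` are the measured pair of the series. In a functional assay on NCI/ADR-RES cells (Homo sapiens) for cytotoxicity, read by sulforhodamine B assay, with a stated time of 48 h (on this read-out higher numbers stand for weaker inhibition of growth and lower numbers for stronger inhibition of growth), compound 1 gives 15800 nM and compound 2 gives 16600 nM. The two numbers lie within the scatter of each other, so compound 1 stands level with its only comparator. Compound 3 `CC1=C(C(=O)Nc2ccc(Cl)c(Cl)c2)C(c2cccc(Oc3ccccc3)c2)NC(=S)N1` differs from compound 1 by phenyl in place of hydrogen on an oxygen on an aromatic ring. Among the measured compounds shown here, no measured pair covers this change, so its size is unknown. The expectation for compound 3 in this assay is a step of a 1.2-fold lower number from compound 1 to compound 3 (0.08 log units; within the scatter), not clearly beyond the scatter in either direction. Compound 3 is therefore estimated at 13000 nM, within a range from 3500 nM to 45000 nM.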

Compound 3, concentration for 50% growth inhibition: 15500 nM
Beside the measured number, compound 3's estimate is 1.2-fold (0.08 log units) below it, and the stated range covers the measured number.
By their numbers in this assay, from the lowest: compounds 3, 1 and 2 (each within the scatter of the next).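

Replacing hydroxy with phenoxy gives a 1.0-fold lower number from compound 1 to compound 3 (0.01 log units; within the scatter) in this assay, so phenyl on this oxygen on an aromatic ring, with its 6 added heavy atoms, leaves the number within the scatter. The free hydroxy of compound 1 is therefore not needed to hold the number at this level, at least against this one replacement. No available evidence bears on this result.

Open, going by these compounds, is how an amine or a carboxylic acid in place of the hydroxy would read. Also open, on these data alone, is how a longer chain on this oxygen would read.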